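The source may report more compounds than this note shows. Statements on the series, on what has been measured and on what is new or still open speak of the compounds shown alone.

Compound 1 `CCCCC1([C@H](O)/C=C/C2[C@H](O)CC(=O)[C@@H]2C/C=C\CCCC(=O)O)CCC1`: 0.00154 mg/kg
Compound 2 `CCCCC1([C@H](O)/C=C/C2CCC(=O)[C@@H]2C/C=C\CCCC(=O)O)CCC1`: 0.0022 mg/kg

Going by the values given here, in a functional assay on the whole organism (strain Hartley) for inhibition, with Cavia porcellus as the target, with stated times of 15 min and 2 min (a higher number here means that more compound is needed for the effect, a lower number that less compound is needed), compound 2 has the highest of the two numbers, but the only measured step, a 1.4-fold higher number from compound 1 to compound 2 (0.15 log units; within the scatter), lies within the scatter. Compound 3 `CCCCC1([C@H](O)/C=C/C2CCC(=O)[C@@H]2CCCCSCC(=O)O)CCC1` differs from compound 2 in its acid-bearing chain: 3-((carboxymethyl)sulfanyl)propyl in place of 5-carboxypent-1-en-1-yl on a saturated chain carbon bound to a saturated ring carbon. That measured step replaced hydroxy with hydrogen on a saturated ring carbon and left this chain untouched, so it gives no direct guide to the new change. Only a modest move towards a higher number is therefore expected, with wide uncertainty. The estimated change is a 1.8-fold higher number from compound 2 to compound 3 (0.26 log units; within the scatter). For compound 3 the estimate is 0.004 mg/kg, with an expected range of 0.0008 mg/kg to 0.02 mg/kg.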

Compound 3, dose for half-maximal effect: 0.0912 mg/kg
The estimate for compound 3 lay 23-fold (1.36 log units) below the measured number, outside the stated range (above it).
By their numbers in this assay, from the lowest: compounds 1 and 2 (each within the scatter of the next); then compound 3.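

In this assay, the acid-bearing chain at this saturated chain carbon proves far more sensitive than the hydroxy on the ring. Replacing 5-carboxypent-1-en-1-yl with 3-((carboxymethyl)sulfanyl)propyl gives a 41-fold higher number from compound 2 to compound 3 (1.62 log units; beyond the scatter), even though the two chains match in heavy-atom count and both carry a carboxy group. Nothing available explains this large step.

The sulfur and the loss of the chain double bond arrive together, and the compounds shown cannot tell them apart. A chain with an oxygen in place of the sulfur, or an all-carbon saturated chain, would separate the two.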